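The compounds below may be only part of what the source reports. "The series", "measured", "known", "first", "only" and "open" are said of these compounds alone.

Series notes. Compound 1 `COc1cc(C(c2ccc(O)c(OC)c2)[C@@H](C)[C@H](C)CF)ccc1O`, compound 2 `COc1ccc(C(c2ccc(OC)c(OC)c2)[C@H](C)[C@@H](C)CO)cc1OC` and compound 3 `COC[C@H](C)[C@@H](C)C(c1ccc(O)c(OC)c1)c1ccc(O)c(OC)c1` share a core and differ in the chain on the saturated chain carbon bound to two aromatic carbons and in the capping of the phenolic oxygens. In a functional assay on HL-60 cells (Homo sapiens) for cytotoxicity, read by WST assay, with a stated time of 48 h (a higher number here means a weaker inhibitor, a lower number a stronger inhibitor), compound 1 gives 32000 nM, compound 2 gives 47000 nM and compound 3 gives 68000 nM. Compound 3 thus carries the highest number of the three, but its gap to compound 2 lies within the scatter, while the step of a 2.1-fold higher number from compound 1 to compound 3 (0.33 log units; beyond the scatter) lies beyond it.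

Compound 4 `COc1cc(C(c2ccc(O)c(OC)c2)[C@@H](CF)C(C)C)ccc1O` is the unmeasured member. It differs from compound 3 by 1-(fluoromethyl)-2-methylpropyl in place of 2-(methoxymethyl)-1-methylpropyl on a saturated chain carbon bound to two aromatic carbons. Within the data shown here, only the step from compound 1 to compound 3 bears on this change, as both swap a methoxymethyl-bearing chain against a fluoromethyl-bearing one, and that step was modest. Running the other way, the expected step for compound 4 is a modest fall, a 1.9-fold lower number from compound 3 to compound 4 (0.29 log units; within the scatter), loosely held since the entering chain is not that of compound 1. Compound 4 is expected to give 35000 nM in this assay, within 15000 nM to 80000 nM.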

Compound 4, half-maximal inhibitory concentration: 39000 nM
Compound 4: middle estimate off by 1.1-fold (0.05 log units), on the low side; measured number inside the range.
By their numbers in this assay, from the lowest: compounds 1, 4, 2 and 3 (each within the scatter of the next, the first and the last beyond it).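

Moving the fluorine-bearing chain from 2-(fluoromethyl)-1-methylpropyl to 1-(fluoromethyl)-2-methylpropyl on the saturated chain carbon bound to two aromatic carbons does not register in this assay, with a 1.2-fold higher number from compound 1 to compound 4 (0.09 log units; within the scatter). The exchange of 2-(methoxymethyl)-1-methylpropyl for 1-(fluoromethyl)-2-methylpropyl, with a 1.7-fold lower number from compound 3 to compound 4 (0.24 log units; within the scatter), also stays inside the scatter, so among the three compounds with free phenolic oxygens only the gap between compound 1 and compound 3 exceeds it. No evidence on the origin of these steps is at hand.

As far as these compounds go, it remains open whether a chain ending in an amine or a carboxylic acid, or a longer chain, at this position would move the number beyond the scatter. Also open, from the compounds shown here alone, is how 1-(fluoromethyl)-2-methylpropyl behaves with methyl ethers on all the phenolic oxygens.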